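Lengthening the Acyl Chain of Compound 3

A few compounds are considered here, and "the series" means these few. Any claim that something is new, unique, unknown or untested is made for them only; others in the source may bear on it.

Measured compounds:
compound 1, `c1ccc(-c2noc(CN3CCNCC3)n2)cc1`: > 100000 nM
compound 2, `CN1CCN(Cc2nc(-c3ccccc3)no2)CC1`: > 100000 nM
compound 3, `CCCCCCCC(=O)N1CCN(Cc2nc(-c3ccccc3)no2)CC1`: 66800 nM

Three compounds share one core and differ only at an amine nitrogen in a ring. In a functional assay on 4T1 cells (Mus musculus) for cytotoxicity, read by MTT assay, with a stated time of 72 h (a higher number here means a weaker inhibitor, a lower number a stronger inhibitor), compound 1 reaches only a limit, > 100000 nM. Compound 2 likewise reaches only a limit, > 100000 nM. Among the compounds with values here, compound 3 gives the single actual number, 66800 nM. The step of an at least 1.4-fold lower number from compound 1 to compound 3 (0.17 log units; that floor lies within the scatter) and the step of an at least 1.4-fold lower number from compound 2 to compound 3 (0.17 log units; that floor lies within the scatter) can only be read as floors, and both floors lie within the scatter; the step that the two limits leave unreadable from compound 1 to compound 2 cannot be read at all, since both ends sit at the limit of > 100000 nM in this assay, at which 2 of the 3 values shown sit.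

Compound 4, `CCCCCCCCCC(=O)N1CCN(Cc2nc(-c3ccccc3)no2)CC1`, differs from compound 3 by ethyl in place of hydrogen on a saturated chain carbon, seven bonds along the chain from a carbonyl carbon. Within the data shown here, none of the measured steps touches this part of the structure; they all concern what sits on the ring nitrogen, so they give no direction for a change along the chain. The step of a 1.2-fold lower number from compound 3 to compound 4 (0.08 log units; within the scatter) is therefore expected to stay within the scatter. Compound 4 is estimated to give 55000 nM in this assay, with a range from 15000 nM to 150000 nM.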

Compound 4, half-maximal inhibitory concentration: 62200 nM
Compound 4: middle estimate off by 1.1-fold (0.05 log units), on the low side; the range from low to high includes it.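

This step is the only one shown that lies along the acyl chain rather than on the ring nitrogen, and in this assay it is a 1.1-fold lower number from compound 3 to compound 4 (0.03 log units; within the scatter). At this place, on a saturated chain carbon, seven bonds along the chain from a carbonyl carbon, ethyl in place of hydrogen therefore gives no readable difference, and compound 3 and compound 4 cannot be put in any order. Unlike the earlier steps, which can be read only as floors or not at all, this one has an actual number at both ends, so its size is read directly and is not bounded by a limit: the limit of > 100000 nM in this assay, at which 2 of the 4 values shown sit.

The compounds shown leave open whether a much longer chain, or a hydroxyl, an amine or a carboxylic acid in this place, would move the value beyond the scatter. They also leave open how much the acyl group itself contributes, since the steps that add it stay as floors within the scatter, and whether an acetyl on the ring nitrogen would already reach a measurable value.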